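Swapping benzyl for 4-aminophenyl on the amide nitrogen

The source may hold more compounds than are shown below. What is called first, only, known or untested is meant among the compounds shown, and "the series" means these compounds.

Of the compounds shown here, three sharing one core have been tested in a functional assay on the whole organism for inhibition, with Rattus norvegicus as the target, read by paw edema, at a dose of 100 mg/kg by the oral route; on this read-out lower numbers stand for less inhibition and higher numbers for more inhibition at the one dose given (going by the name of the read-out). Compound 1 `O=C(Nc1ccccn1)c1c(O)c2cccnc2n(-c2ccccc2)c1=O` gives -13.5%, compound 2 `O=C(NCc1ccccc1)c1c(O)c2cccnc2n(-c2ccccc2)c1=O` gives 1.6%, and compound 3 `O=C(Nc1ccc(Cl)cc1)c1c(O)c2cccnc2n(-c2ccccc2)c1=O` gives 11.6%. Compound 2 thus stands second highest of the three numbers: its nearest neighbour is compound 3, with a gap within the scatter, and its furthest is compound 1, with a gap beyond it.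

Compound 4 `Nc1ccc(NC(=O)c2c(O)c3cccnc3n(-c3ccccc3)c2=O)cc1` differs from compound 2 in one place: 4-aminophenyl in place of benzyl on an amide-type nitrogen. The closest measured step is a number 10 percentage points higher from compound 2 to compound 3 (within the scatter), where benzyl also gave way to a phenyl ring carrying a single group, but that rise stayed within the scatter. The larger step of a number 25.1 percentage points higher from compound 1 to compound 3 (beyond the scatter) and the smaller a number 15.1 percentage points higher from compound 1 to compound 2 (beyond the scatter) concern a different group leaving and only show that substituted phenyl sits at the top of this small set. Going by the values given here, no measured step covers an amino group itself.

Compound 4 is therefore expected to show a step of a number 6.4 percentage points higher from compound 2 to compound 4 (within the scatter), a change not clearly beyond the scatter. The estimate for compound 4 is 8%, expected between -10% and 26%.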

Compound 4, a percentage reported as inhibition, in the whole organism at one dose (the size of the read-out at that dose, not a potency): -5.5%
Compound 4: middle estimate off by 13.5 percentage points, on the high side; low and high end bracket the measured number.
By their numbers in this assay, from the lowest: compounds 1, 4, 2 and 3 (each within the scatter of the next, the first and the last beyond it).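

In this assay, replacing benzyl with 4-aminophenyl on the amide nitrogen gives a number 7.1 percentage points lower from compound 2 to compound 4 (within the scatter), and replacing pyridin-2-yl with the same group gives a number 8 percentage points higher from compound 1 to compound 4 (within the scatter), so neither change separates these groups on this read-out. The new information comes from keeping the phenyl ring and changing only the group it carries: amino in place of chloro gives a number 17.1 percentage points lower from compound 3 to compound 4 (beyond the scatter), so at this position a phenyl ring alone does not settle the number, and the group on that ring counts as well. No evidence is available to explain this difference between amino and chloro.

The compounds shown leave open how a methoxy group or a carboxylic acid in place of the amino group would read, and where a bare phenyl ring would stand. With a single dose, they also leave potency open.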